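A few compounds are considered here, and "the series" means these few. Any claim that something is new, unique, unknown or untested is made for them only; others in the source may bear on it.

Three compounds share one core and differ only in the group on the outer phenyl ring. Compound 1 `Cc1c(O)c(=O)ccn1CC(=O)N/N=C1\C(=O)N(CC(=O)Nc2ccc(Br)cc2)c2ccccc21` gives 32500 nM in a functional assay on MCF7 cells (Homo sapiens) for cytotoxicity, read by MTT assay, with a stated time of 48 h; on this read-out lower numbers stand for an effect already at smaller amounts and higher numbers for an effect only at larger amounts of compound. Compound 2 `Cc1c(O)c(=O)ccn1CC(=O)N/N=C1\C(=O)N(CC(=O)Nc2ccc(Cl)cc2)c2ccccc21` gives 31400 nM in this assay. Compound 3 `Cc1ccc(NC(=O)CN2C(=O)/C(=N\NC(=O)Cn3ccc(=O)c(O)c3C)c3ccccc32)cc1` gives 52200 nM in this assay. On these numbers compound 3 sits alongside the other two rather than apart from them: there is a 1.6-fold higher number from compound 1 to compound 3 (0.21 log units; within the scatter) and a 1.7-fold higher number from compound 2 to compound 3 (0.22 log units; within the scatter), and between the first pair a 1.0-fold lower number from compound 1 to compound 2 (0.01 log units; within the scatter). Compound 4 `CC(=O)Nc1ccc(NC(=O)CN2C(=O)/C(=N\NC(=O)Cn3ccc(=O)c(O)c3C)c3ccccc32)cc1` differs from compound 3 by acetamido in place of methyl on an aromatic carbon. All three measured steps concern exactly this position of the ring, and none of them moved the number beyond the scatter, which speaks for a fourth substituent at the same place behaving alike. Within the data shown here, the measured set holds no example of a group with a hydrogen-bond donor or a hydrogen-bond acceptor at this position, so the expectation rests on an extrapolation from halogen and methyl alone and carries that uncertainty. Compound 4 is expected to give about 50000 nM in this assay, with a likely range from 20000 nM to 125000 nM, which amounts to an expected step of a 1.0-fold lower number from compound 3 to compound 4 (0.02 log units; within the scatter).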

Compound 4, half-maximal effective concentration: 51900 nM
Compound 4: the middle estimate sits 1.0-fold (0.02 log units) below what was measured, within the range that was stated.
By their numbers in this assay, from the lowest: compounds 2, 1, 4 and 3 (each within the scatter of the next).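

Acetamido brings to this place what none of the earlier groups had, a hydrogen-bond donor and a hydrogen-bond acceptor, and it has 4 heavy atoms where methyl has 1, yet in this assay the change gives a 1.0-fold lower number from compound 3 to compound 4 (0.00 log units; within the scatter) and so does not separate the two compounds. Against the halogens the outcome is the same, with a 1.7-fold higher number from compound 2 to compound 4 (0.22 log units; within the scatter) and a 1.6-fold higher number from compound 1 to compound 4 (0.20 log units; within the scatter) both remaining within the scatter. On an aromatic carbon para to a large group, bromo, chloro, methyl and acetamido therefore cannot be told apart in this read-out, and no evidence in hand bears on why the number stays flat across them.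

From the compounds shown here alone, whether an amine, a carboxylic acid or a longer chain at this place would carry the number beyond the scatter remains open. So does whether a change to the shared core itself would shift the number in a way that these four groups on the outer phenyl ring did not.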